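Aryl change on the 2-hydroxyethoxy compound

This account rests on a few compounds, and the source may have more. Where it says the series, first, only, none or still open, it means among the compounds named here.

Measured in a toxicity assay on HaCaT cells (Homo sapiens) for cytotoxicity, read by CCK-8 assay, with a stated time of 24 h (a lower number here means that less compound is tolerated, a higher number that more compound is tolerated), so far
- compound 1 `COc1ccccc1Oc1c(N)nc(-c2ccc(C)cc2)nc1Cl` gives 6300 nM
- compound 2 `COc1ccccc1Oc1c(N)nc(-c2ccc(F)cc2)nc1Cl` gives 42600 nM
- compound 3 `COc1ccccc1Oc1c(N)nc(-c2ccc(C)cc2)nc1OCCO` gives 56600 nM

Compound 3 lies within the scatter of compound 2 and clear of compound 1, with a 9.0-fold higher number from compound 1 to compound 3 (0.95 log units; beyond the scatter) on record. Compound 4 `COc1ccccc1Oc1c(N)nc(-c2ccccc2F)nc1OCCO` carries one change, 2-fluorophenyl in place of 4-methylphenyl on an aromatic carbon on the shared core. The closest measured change is a 6.8-fold higher number from compound 1 to compound 2 (0.83 log units; beyond the scatter) for fluoro in place of methyl, but that step kept chloro on the core, and the fluoro position in compound 4 is its own. For the measured compounds named here, no such step has been measured with 2-hydroxyethoxy present. The expected step is a 1.1-fold higher number from compound 3 to compound 4 (0.06 log units; within the scatter) and so none beyond the scatter in this assay for now. For compound 4 the estimated value is 65000 nM with an expected range from 25000 nM to 150000 nM here.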

Compound 4, half-maximal cytotoxic concentration: 39500 nM
Beside the measured number, compound 4's estimate is 1.6-fold (0.22 log units) above it; the range from low to high includes it.
By their numbers in this assay, from the lowest: compound 1; then compounds 4, 2 and 3 (each within the scatter of the next).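

In this assay, the aryl position with 2-hydroxyethoxy on the core shows a 1.4-fold lower number from compound 3 to compound 4 (0.16 log units; within the scatter) for 2-fluorophenyl in place of 4-methylphenyl, so these two aryl groups are not told apart here. The earlier aryl step, a 6.8-fold higher number from compound 1 to compound 2 (0.83 log units; beyond the scatter) with chloro on the core, is a different change with its own fluoro position, and it does not carry over to this pair. Nothing on hand offers an explanation for this reading.

Still open, from the compounds shown here alone, is how this position behaves with an aryl group carrying an amine or a carboxylic acid. Also open, going by these compounds, is whether 2-fluorophenyl gives a similar reading with chloro in place of 2-hydroxyethoxy.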